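A few compounds are considered here, and "the series" means these few. Any claim that something is new, unique, unknown or untested is made for them only; others in the source may bear on it.

Measured compounds and their values:

compound 1 `CC(=O)N1N=C(c2ccc(-n3ccnc3)cc2)CC1c1ccc(N(C)C)cc1`: 5%
compound 2 `C=C(C)C(=O)N1N=C(c2ccc(-n3ccnc3)cc2)CC1c1ccc(N(C)C)cc1`: 4.3%
compound 3 `COC(=O)CC(=O)N1N=C(c2ccc(-n3ccnc3)cc2)CC1c1ccc(N(C)C)cc1`: 2.3%

In a functional assay on MDA-MB-231 cells (Homo sapiens) for inhibition, read by sulforhodamine B assay, tested at 10 uM (on this read-out higher numbers stand for more inhibition at the one concentration tested (going by the name of the read-out) and lower numbers for less inhibition), compound 3 gives 2.3%, the smallest of the three numbers, although the gaps a number 2.7 percentage points lower from compound 1 to compound 3 (within the scatter) and a number 2 percentage points lower from compound 2 to compound 3 (within the scatter) are both small. Compound 4 `CN(C)c1ccc(C2CC(c3ccc(-n4ccnc4)cc3)=NN2C(=O)c2ccc(C(F)(F)F)cc2)cc1` differs from compound 3 in one place: 4-(trifluoromethyl)phenyl in place of (methoxycarbonyl)methyl on a carbonyl carbon. The measured steps that bear on this all change the group on the same carbonyl carbon: a number 0.7 percentage points lower from compound 1 to compound 2 (within the scatter), a number 2.7 percentage points lower from compound 1 to compound 3 (within the scatter) and a number 2 percentage points lower from compound 2 to compound 3 (within the scatter). None of them moved the read-out beyond the scatter. Within the data shown here, the entering group is larger than any tried so far, but with no step that crossed the scatter, no change beyond the scatter is expected for compound 4, so a number 1.7 percentage points higher from compound 3 to compound 4 (within the scatter) is the estimate. Compound 4 is therefore expected to give 4%, within 0% to 12%.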

Compound 4, a percentage reported as inhibition, at one concentration (the size of the read-out at that concentration, not a potency): 17.9%
Compound 4: the middle estimate sits 13.9 percentage points below what was measured; measured number outside the range, above it.
By their numbers in this assay, from the lowest: compounds 3, 2 and 1 (each within the scatter of the next); then compound 4.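

On the carbonyl carbon bound to the amide-type nitrogen in a ring, the choice of group can move the read-out in this assay after all: 4-(trifluoromethyl)phenyl gives a number 15.6 percentage points higher from compound 3 to compound 4 (beyond the scatter) and a number 13.6 percentage points higher from compound 2 to compound 4 (beyond the scatter) and also a number 12.9 percentage points higher from compound 1 to compound 4 (beyond the scatter) while swaps among the three groups without a ring stayed within the scatter. Nothing available explains this rise. On these data alone, whether the aromatic ring alone is enough, or the trifluoromethyl on it is also needed, stays open. Plain phenyl, or a phenyl carrying an amine or a carboxylic acid in place of trifluoromethyl, would help separate the two.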